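The source may report more compounds than this note shows. Statements on the series, on what has been measured and on what is new or still open speak of the compounds shown alone.

Measured in a functional assay on KB cells (Homo sapiens) for antiproliferative activity, read by MTT assay, with a stated time of 48 h; a lower number here means a stronger inhibitor, a higher number a weaker inhibitor:
- compound 1 `Cn1cc(C2=C(c3nn(CCn4ccnc4)c4ncccc34)C(=O)N(c3ccccc3)C2=O)c2ccccc21`: > 100000 nM, a limit and not a number
- compound 2 `CN(C)CCCn1nc(C2=C(c3cn(C)c4ccccc34)C(=O)N(c3ccccc3)C2=O)c2cccnc21`: 14100 nM

Going by the values given here, compound 2 is the only compound with an actual number, 14100 nM. The one other result, that of compound 1, is a limit. Compound 3 `Cn1cc(C2=C(c3nn(CCCn4cccc4)c4ncccc34)C(=O)N(c3ccccc3)C2=O)c2ccccc21` differs from compound 2 by 1H-pyrrol-1-yl in place of dimethylamino on a saturated chain carbon, three bonds along the chain from an aromatic nitrogen: 1H-pyrrol-1-yl in place of dimethylamino, on a saturated chain carbon, three bonds along the chain from an aromatic nitrogen.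

Among the compounds with values here, one measured step bears on this change, an at least 7.0-fold lower number from compound 1 to compound 2 (0.85 log units; beyond the scatter), in which a chain ending in 1H-imidazol-1-yl gives way to one ending in dimethylamino. Compound 3 reverses that kind of change by again ending its chain in an aromatic ring, so a move toward a higher number is expected. The expected size is similar, an estimated 3.5-fold higher number from compound 2 to compound 3 (0.55 log units; beyond the scatter). In this assay, compound 3 is expected at 50000 nM, with an estimated range of 15000 nM to 150000 nM.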

Compound 3, half-maximal inhibitory concentration: > 100000 nM
Compound 3: a limit, no number; the forecaster's own chance of this, stated with the estimate: 45%; middle value at least 2.0-fold (0.30 log units) from the limit.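

In this assay, 3-(1H-pyrrol-1-yl)propyl in place of 3-(dimethylamino)propyl gives an at least 7.0-fold higher number from compound 2 to compound 3 (0.85 log units; beyond the scatter). On these data alone, compound 3 reads > 100000 nM, which is a limit and not a number, so the true size of this step stays unknown. Among the compounds shown, only the chain ending in dimethylamino gives a readable number, and the step between compound 1 and compound 3 cannot be read, since both stop at the same limit: the limit of > 100000 nM in this assay, at which 2 of the 3 values shown sit.

As far as these compounds go, it remains open whether another amine at the end of this chain, such as a pyrrolidine, a piperidine or a morpholine, would also give a readable number. Also open, from the compounds shown here alone, is how a shorter or longer chain carrying dimethylamino would compare with compound 2.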